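This account rests on a few compounds, and the source may have more. Where it says the series, first, only, none or still open, it means among the compounds named here.

In a functional assay on RS4-11 cells (Homo sapiens) for inhibition, read by CCK-8 assay, with a stated time of 48 h, tested at 20 uM (a lower number here means less inhibition of growth, a higher number more inhibition of growth at the concentration tested), compound 3 `COc1ccc(S(=O)(=O)Oc2ccccc2/C=C(\C#N)C(=O)Nc2nnc(Cc3ccc(C)cc3)s2)cc1` gives 79%, level with compound 1 `COc1ccc(Cc2nnc(NC(=O)/C(C#N)=C/c3ccccc3OS(=O)(=O)c3ccc(Cl)cc3)s2)cc1` at 79%. Compound 2 `N#C/C(=C\c1ccccc1OS(=O)(=O)c1ccc(Cl)cc1)C(=O)Nc1nnc(Cc2ccc(F)cc2)s1` stands lower at 68%.

The next structure is compound 4 `Cc1ccc(Cc2nnc(NC(=O)/C(C#N)=C/c3ccccc3OS(=O)(=O)c3ccc(Cl)cc3)s2)cc1`. Its change from compound 3 is chloro in place of methoxy on an aromatic carbon, para to a large group, so that (4-methoxyphenyl)sulfonyl becomes (4-chlorophenyl)sulfonyl.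

Among the compounds with values here, no measured step covers this exchange at this place. Within the data shown here, the one measured step, a number 11 percentage points lower from compound 1 to compound 2 (beyond the scatter), is modest and also replaces a methoxy, but with fluoro and elsewhere in the molecule, so it bears only indirectly. More relevant is compound 1, which already carries the (4-chlorophenyl)sulfonyl group and gives 79%, level with compound 3. In this assay no step beyond the scatter is therefore expected, though the data leave this untested.

The expected change is a number 3 percentage points lower from compound 3 to compound 4 (within the scatter). For compound 4 the estimate is 76%, with an expected range of 64% to 87%.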

Compound 4, percent growth inhibition at one concentration: 72%
Beside the measured number, compound 4's estimate is 4 percentage points above it, within the range that was stated.
By their numbers in this assay, from the lowest: compounds 2, 4, 1 and 3 (each within the scatter of the next, the first and the last beyond it).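

In this assay, the exchange of (4-methoxyphenyl)sulfonyl for (4-chlorophenyl)sulfonyl can now be read directly, with the rest of the molecule held constant: a number 7 percentage points lower from compound 3 to compound 4 (within the scatter), so this place accepts chloro in place of methoxy without a step beyond the scatter. At the other changing aromatic position, methyl stays within the scatter of both neighbours, with a number 7 percentage points lower from compound 1 to compound 4 (within the scatter) and a number 4 percentage points higher from compound 2 to compound 4 (within the scatter), even though a number 11 percentage points lower from compound 1 to compound 2 (beyond the scatter) lies beyond it, so methyl cannot be ranked against methoxy or fluoro. Nothing available gives a reason for these readings.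

The compounds shown leave open how an amine or a carboxylic acid would read in place of chloro or methoxy on the sulfonyl-bearing ring. From the compounds shown here alone, a longer chain at the same place is equally open.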